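Imidazolylmethyl biaryls: alpha-ethyl branching in compound 4

The source may report more compounds than this note shows. Statements on the series, on what has been measured and on what is new or still open speak of the compounds shown alone.

Measured so far:
- compound 1 `CSc1ccc(-c2ccc(Cn3ccnc3)cc2)s1`: 3%
- compound 2 `Fc1ccc(-c2csc(Cn3ccnc3)c2)cc1`: 0%
- compound 3 `Fc1ccc(-c2ccc(Cn3ccnc3)cc2)cn1`: 4%

In an assay for inhibition of steroid 17-alpha-hydroxylase/17,20 lyase (Homo sapiens), using NADPH, tested at 0.2 uM (on this read-out higher numbers stand for a stronger effect at the one concentration tested and lower numbers for a weaker effect), compound 1 gives 3%. Compound 3 gives 4% and compound 2 gives 0% in this assay; all three numbers lie within the scatter of one another, so no order among compound 1, compound 2 and compound 3 can be read from them. Compound 1 stands among three essentially flat results, none of which is distinguishable from the others.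

Compound 4 `CCC(c1ccc(-c2ccc(SC)s2)cc1)n1ccnc1` is the next compound to be measured. Compared with compound 1 the change is ethyl in place of hydrogen on a saturated chain carbon bound to an aromatic carbon and an aromatic nitrogen. For the measured compounds named here, no step between measured compounds bears on this change, since none of the three differs from another in one place.

The flat numbers of compound 1, compound 2 and compound 3 give no reason to expect a large move in this assay. Compound 4 is expected to stay close to compound 1, with a number 5 percentage points higher from compound 1 to compound 4 (within the scatter) estimated as a step of no more than the scatter, if any, and a weak effect at the single concentration. The estimate for compound 4 is 8%, with a range from 0% to 30%.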

Compound 4, a percentage reported as inhibition, at one concentration (the size of the read-out at that concentration, not a potency): 2%
Compound 4: the middle estimate sits 6 percentage points above what was measured; measured number inside the range.
By their numbers in this assay, from the lowest: compounds 2, 4, 1 and 3 (each within the scatter of the next).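

In this assay, for the compounds shown here, ethyl in place of hydrogen on a saturated chain carbon bound to an aromatic carbon and an aromatic nitrogen gives a number 1 percentage points lower from compound 1 to compound 4 (within the scatter) and this is the only step so far that isolates a change in one place. With compound 1 at 3% on this read-out, the step shows no gain from ethyl at this carbon at the one concentration tested, and a loss would have little room to appear so close to the bottom of the scale. Nothing measured in the series accounts for the size of this step or links it to any property of the ethyl group.

Open, on these data alone, is whether methyl, a longer chain such as propyl, or a hydroxyl or an amine on the same carbon would lift the number in this assay above the scatter around compound 1. Also open, as far as these compounds go, is whether ethyl on this carbon would behave the same way on the cores of compound 2 and compound 3, and whether any of these flat results hides a difference in potency that one concentration cannot reveal.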